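Cyclopentyl in place of cyclopropyl at the imine nitrogen

This account rests on a few compounds, and the source may have more. Where it says the series, first, only, none or still open, it means among the compounds named here.

The series rests on the core of compound 1 `CCCC/N=C(\NC#N)Nc1cccnc1`, which in a functional assay on the whole organism (blood, strain Wistar-Okamoto) with Rattus norvegicus as the target, with a stated time of 5 days (a lower number here means that less compound is needed, a higher number that more compound is needed for the effect), gives 20 mg/kg. Compound 2 `N#CN/C(=N\C1CC1)Nc1cccnc1` carries cyclopropyl in place of butyl on a double-bonded nitrogen; in this assay compound 2 gives 20 mg/kg. For the measured compounds named here, that exchange gave no change at the digits printed from compound 1 to compound 2 (within the scatter), so on the numbers so far compound 2 stands level with compound 1, and no other measured compound sits near enough to place it further.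

Compound 3 `N#CN/C(=N\C1CCCC1)Nc1cccnc1` is the next member, not yet measured. Against compound 2 the change is cyclopentyl in place of cyclopropyl on a double-bonded nitrogen. Going by the values given here, the only measured step at this position is no change at the digits printed from compound 1 to compound 2 (within the scatter), which stayed within the scatter when a ring replaced an open chain. The five-membered ring is new to the series, and nothing measured points up or down for it. On that basis the expected step is no change at the digits printed from compound 2 to compound 3 (within the scatter), none beyond the scatter, with a wider range to allow for the untested ring. For compound 3 the estimate in this assay is 20 mg/kg, with a range from 10 mg/kg to 40 mg/kg.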

Compound 3, minimum effective dose: 20 mg/kg
Compound 3: the middle estimate sits on the measured number at the digits printed, and the stated range covers the measured number.
By their numbers in this assay, from the lowest: compounds 1, 2 and 3 (each within the scatter of the next).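

Notes on the imine nitrogen position: in this assay, cyclopentyl in place of cyclopropyl on a double-bonded nitrogen gives no change at the digits printed from compound 2 to compound 3 (within the scatter), and cyclopentyl in place of butyl gives no change at the digits printed from compound 1 to compound 3 (within the scatter). The earlier pair set a ring only against an open chain; this result also sets two ring sizes against each other, 3 heavy atoms against 5, and the minimum effective dose does not separate them. Butyl, cyclopropyl and cyclopentyl therefore read alike at this position, and no supporting measurement is available to explain that flat result.

From the compounds shown here alone, all three groups contain carbon only, so it remains open whether an amine, a carboxylic acid or a chain longer than butyl at this position would read at the same level. The shared core is also constant across the three compounds, which leaves open whether this flat reading would hold with any other part of the structure changed.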